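Swapping an ether link for an amine link in the core

The source may report more compounds than this note shows. Statements on the series, on what has been measured and on what is new or still open speak of the compounds shown alone.

Compound 1 `COc1ccc(Oc2ccc3cc(NC(=O)c4ccc(OC(C)=O)c(CC=C(C)C)c4)c(=O)oc3c2C)cc1` and compound 2 `COc1ccc(Oc2ccc3cc(NC(=O)c4ccc(O)c(CC=C(C)C)c4)c(=O)oc3c2C)cc1` were measured in a functional assay on SK-BR-3 cells (Homo sapiens) for antiproliferative activity; on this read-out lower numbers stand for stronger inhibition and higher numbers for weaker inhibition. Compound 1 gives 19500 nM, the lowest of the two numbers, while compound 2 gives 42700 nM; the step of a 2.2-fold higher number from compound 1 to compound 2 (0.34 log units; beyond the scatter) is the only one known. Compound 3 `COc1ccc(Nc2ccc3cc(NC(=O)c4ccc(OC(C)=O)c(CC=C(C)C)c4)c(=O)oc3c2C)cc1` is not yet measured and differs from compound 1 by (4-methoxyphenyl)amino in place of 4-methoxyphenoxy on an aromatic carbon. Going by the values given here, no measured step touches this change, since the known step concerns the acetyl on the other ring. With no guidance, compound 3 is expected to stay close to compound 1, with the estimated step of a 1.0-fold higher number from compound 1 to compound 3 (0.01 log units; within the scatter). Compound 3 is therefore estimated at 20000 nM, within 6000 nM to 70000 nM.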

Compound 3, half-maximal inhibitory concentration: > 100000 nM
Compound 3 ended at the assay's limit; the forecaster's own chance of this, stated with the estimate: 15%; middle value at least 5.0-fold (0.69 log units) away from the limit.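

The earlier step touched only the acetyl on the other ring, whereas this one shows that the link at this position matters: in this assay, (4-methoxyphenyl)amino in place of 4-methoxyphenoxy gives an at least 5.1-fold higher number from compound 1 to compound 3 (0.70 log units; beyond the scatter). Compound 3 gives > 100000 nM, which is a limit of the assay and not a number: the limit of > 100000 nM in this assay, at which 1 of the 3 values shown sits.

Still open, as far as these compounds go, is whether a sulfur link or a methylene link at this position would keep the number close to that of compound 1. Also open, from the compounds shown here alone, is whether a free hydroxyl in place of the acetyl would change anything alongside the amine link.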